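Trifluoromethyl to nitro at the limit of the assay

A few compounds are considered here, and "the series" means these few. Any claim that something is new, unique, unknown or untested is made for them only; others in the source may bear on it.

Measured in a functional assay on CEM-SS cells (Homo sapiens) for cytotoxicity; a lower number here means a stronger inhibitor, a higher number a weaker inhibitor:
Compound 1 `Nc1nc2cc(Cl)c(Cl)cc2n1Cc1cccc([N+](=O)[O-])c1`: 47000 nM
Compound 2 `Clc1cccc(Cn2c(Br)nc3cc(Cl)c(Cl)cc32)c1`: > 100000 nM (a limit)
Compound 3 `FC(F)(F)c1cccc(Cn2c(Br)nc3cc(Cl)c(Cl)cc32)c1`: > 100000 nM (a limit)

Compound 3 gives > 100000 nM, which is a limit of the assay and not a number. Its true position on the scale is therefore unknown. Going by the values given here, the values so far gather at one end: the limit of > 100000 nM in this assay, at which 2 of the 3 values shown sit.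

Compound 4 `O=[N+]([O-])c1cccc(Cn2c(Br)nc3cc(Cl)c(Cl)cc32)c1` has not yet been measured. It differs from compound 3 by one change: nitro in place of trifluoromethyl on an aromatic carbon. This puts nitro in place of trifluoromethyl on an aromatic carbon, meta to a large group.

Among the compounds with values here, only one measured step is of a similar kind, a swap of one group on an aromatic carbon: a step that the two limits leave unreadable from compound 2 to compound 3. It offers no size to carry over. Within the data shown here, compound 1, the only measured compound that carries a nitro group, gives 47000 nM, a true number. This single value leaves room for a nitro compound to give a reading in this assay, so a modest step towards stronger inhibition is expected, and another limit is quite possible. The estimated step is an at least 1.2-fold lower number from compound 3 to compound 4 (0.09 log units; that floor lies within the scatter). For compound 4 the expected value is 80000 nM, with an estimated range from 30000 nM to 150000 nM.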

Compound 4, half-maximal inhibitory concentration: > 100000 nM
Compound 4 gave a limit, no number; the forecaster's own chance of this, stated with the estimate: 60%; middle value at least 1.2-fold (0.09 log units) away from the limit.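

In this assay compound 4 gives > 100000 nM, which is a limit of the assay and not a number. Nitro on this aromatic carbon therefore joins chloro and trifluoromethyl without giving a reading, so the steps among compound 2, compound 3 and compound 4 cannot be read, and all three of these compounds stay at the top of the scale: the limit of > 100000 nM in this assay, at which 3 of the 4 values shown sit.

On these data alone, with the nitro group held in place, the comparison with the other nitro compound gives an at least 2.1-fold higher number from compound 1 to compound 4 (0.32 log units; beyond the scatter), so bromo in place of amino on an aromatic carbon is a change whose effect on this read-out lies beyond the scatter, though its full size remains unknown.

The compounds shown leave open whether chloro, trifluoromethyl and nitro differ from one another at all in this read-out, as none of the three gives a number alongside bromo. As far as these compounds go, it also remains open whether a carboxylic acid or a methoxy group on this aromatic carbon would give a number, and whether amino in place of bromo would do so with chloro or trifluoromethyl on the aromatic carbon.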